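The source may report more compounds than this note shows. Statements on the series, on what has been measured and on what is new or still open speak of the compounds shown alone.

Measured so far:
- compound 1, `COc1ccc(C(CCCCCCN2CCc3cc(OC)c(OC)cc3C2)Sc2ccc(C)cc2)cc1OC`, in a physicochemical assay for lipophilicity (a higher number here means a more lipophilic compound, a lower number a more polar compound), compound 1 gives 7.95
- compound 2, `COc1ccc(C(CCCCCN2CCc3cc(OC)c(OC)cc3C2)SC2CCCCC2)cc1OC`, in this assay compound 2 gives 7.33

For the measured compounds named here, of the two numbers known, the value of compound 2 is the lower one; compound 1 stands higher, and that gap is beyond the usual scatter of this assay. Going by the values given here, no single-point step between measured compounds has been recorded, so nothing about the effect of swapping one group for another has yet been seen directly.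

Compound 3, `CCCCCSC(CCCCCN1CCc2cc(OC)c(OC)cc2C1)c1ccc(OC)c(OC)c1`, has not been measured. It is made from compound 2 by one change: pentyl in place of cyclohexyl on a sulfur. The leaving group and the entering group are both made only of carbon and carry no donor or acceptor, so a large shift in either direction is not expected; the step of a number 0.23 log units lower from compound 2 to compound 3 (within the scatter) is expected to be small, at most at the edge of the scatter, downward if anything. Compound 3 is therefore estimated at 7.1, with a range from 6.7 to 7.5.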

Compound 3, partition coefficient: 5.66
Compound 3: middle estimate off by 1.44 log units, on the high side; measured number below the stated range.
By their numbers in this assay, from the lowest: compound 3; then compound 2; then compound 1.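

On a sulfur in this series, the choice of group matters a great deal in this assay: pentyl in place of cyclohexyl gives a large change (a number 1.67 log units lower from compound 2 to compound 3 (beyond the scatter)). Both groups are made only of carbon, with no hydrogen-bond donors or acceptors and no net charge, yet opening the ring into a chain moves the number well beyond the scatter, so matching these counts does not guarantee similar values here. What lies behind a step of this size cannot be said from the data at hand.

This single pair leaves open whether the ring itself or the overall shape of the group carries the step. A cyclopentyl or a hexyl group on the same sulfur would help separate the ring from the size of the group.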